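The compounds below may be only part of what the source reports. "The series", "measured", "known", "first", "only" and "open" are said of these compounds alone.

Measured compounds in a functional assay on HCT-116 cells (Homo sapiens) for inhibition, read by MTT assay, with a stated time of 48 h; on this read-out higher numbers stand for weaker inhibition and lower numbers for stronger inhibition:
- compound 1 `COc1ccc(CN(C(=O)CCl)c2cc(OC)c(OC)c(OC)c2)cc1O` gives 250 nM
- compound 3 `C/C=C/C(=O)N(Cc1ccc(OC)c([N+](=O)[O-])c1)c1cc(OC)c(OC)c(OC)c1` gives 670 nM
- compound 2 `COC(=O)c1cc(CNc2cc(OC)c(OC)c(OC)c2)ccc1OC` gives 38100 nM

Compound 1 has the lowest number of the three; compound 3 comes nearest, its number higher by a margin beyond the scatter, and compound 2 lies far above both. Compound 4 `COc1ccc(CN(C(=O)CN=[N+]=[N-])c2cc(OC)c(OC)c(OC)c2)cc1O` is not yet measured. It differs from compound 1 in one place: azido in place of chloro on a saturated chain carbon bound to a carbonyl carbon. For the measured compounds named here, no step between measured compounds shows a change of this kind, so the expected effect rests only on the change itself. The step of a 6.0-fold higher number from compound 1 to compound 4 (0.78 log units; beyond the scatter) is expected to run toward weaker inhibition, by a margin somewhat beyond the scatter. Compound 4 is expected to give about 1500 nM, within a range from 400 nM to 6000 nM.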

Compound 4, half-maximal inhibitory concentration: 410 nM
Beside the measured number, compound 4's estimate is 3.7-fold (0.56 log units) above it; low and high end bracket the measured number.
By their numbers in this assay, from the lowest: compounds 1, 4 and 3 (each within the scatter of the next, the first and the last beyond it); then compound 2.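

In this assay, azido in place of chloro on a saturated chain carbon bound to a carbonyl carbon gives a 1.6-fold higher number from compound 1 to compound 4 (0.21 log units; within the scatter). On the shared core, chloro is therefore not required at this position for this level of inhibition, and azido, with 3 heavy atoms against 1, serves equally within the scatter. Nothing available explains this outcome. Still open, on these data alone, is whether an amine, a hydroxyl or a thiol on this carbon would keep the number at this level. As far as these compounds go, a longer chain in place of azidomethyl is equally open.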